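Chain branching on the shared core: ethyl to isopropyl

This account rests on a few compounds, and the source may have more. Where it says the series, first, only, none or still open, it means among the compounds named here.

Three compounds have numbers in a functional assay on HepG2 cells (Homo sapiens) for inhibition, read by sulforhodamine B assay, with a stated time of 72 h, tested at 10 uM; on this read-out lower numbers stand for less inhibition and higher numbers for more inhibition at the one concentration tested (going by the name of the read-out). Compound 1 `C[C@H](Nc1ncnc2[nH]cnc12)c1nn(-c2cccnc2)c2cc(F)ccc12` gives 23% in this assay. Compound 2 `CC[C@H](Nc1ncnc2[nH]cnc12)c1nn(-c2cccnc2)c2cc(F)ccc12` gives 26%, and compound 3 `C[C@H](Nc1ncnc2[nH]cnc12)c1nn(-c2cc(F)cc(F)c2)c2cc(F)ccc12` gives 30%. Compound 2 stands second of the three, and both its neighbours lie within the scatter of it: the step of a number 3 percentage points higher from compound 1 to compound 2 (within the scatter) is within the scatter, as is the gap of compound 2 to compound 3. The remaining measured step, a number 7 percentage points higher from compound 1 to compound 3 (within the scatter), is also within the scatter, so nothing among these three compounds rises above the usual spread of repeats.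

Compound 4 `CC(C)[C@H](Nc1ncnc2[nH]cnc12)c1nn(-c2cccnc2)c2cc(F)ccc12` is not yet measured. It differs from compound 2 by methyl in place of hydrogen on a saturated chain carbon bound to two saturated chain carbons, which extends the same saturated chain that was grown once already between compound 1 and compound 2. That earlier growth, a number 3 percentage points higher from compound 1 to compound 2 (within the scatter), bears directly on the present step and did not move the read-out beyond the scatter. The change from compound 3 does not bear on it, since compound 3 differs at the aromatic nitrogen.

For compound 4 in this assay a step of a number 1 percentage points higher from compound 2 to compound 4 (within the scatter) is therefore expected, which is no change beyond the scatter. Compound 4 is estimated at 27%, with a range from 15% to 40%.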

Compound 4, a percentage reported as inhibition, at one concentration (the size of the read-out at that concentration, not a potency): 16%
For compound 4 the middle estimate is 11 percentage points above the measured one, and the stated range covers the measured number.
By their numbers in this assay, from the lowest: compounds 4, 1, 2 and 3 (each within the scatter of the next, the first and the last beyond it).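

In this assay the series now includes a branched group at this saturated chain carbon: isopropyl in place of ethyl gives a number 10 percentage points lower from compound 2 to compound 4 (within the scatter) and isopropyl in place of methyl gives a number 7 percentage points lower from compound 1 to compound 4 (within the scatter). Methyl, ethyl and isopropyl on this carbon, all with pyridin-3-yl on the aromatic nitrogen, therefore lie within the scatter of one another, so neither unbranched nor branched growth of the chain separates from the usual spread of repeats in these three compounds. No measurement at hand offers an explanation of the values at this position.

On these data alone, whether a longer chain such as n-butyl, a ring such as cyclopropyl or a hydroxyl group at this carbon would stay inside the same spread remains open. Also open, as far as these compounds go, is whether isopropyl gives a similar read-out with 3,5-difluorophenyl on the aromatic nitrogen, and how these compounds would compare across a range of concentrations, as a single-concentration read-out is not a potency.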